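The source may hold more compounds than are shown below. What is called first, only, known or untested is meant among the compounds shown, and "the series" means these compounds.

In a functional assay on NALM-6 cells (Homo sapiens) for cytotoxicity, read by MTT assay, with a stated time of 46 h (a lower number here means a stronger inhibitor, a higher number a weaker inhibitor), compound 1 (`O=C1/C(=C\c2ccncc2)C(c2ccccc2)Oc2ccccc21`) gives 700 nM as a measured value. Compound 2 (`O=C1/C(=C\c2ccccc2)C(c2ccccc2)Oc2ccccc21`) gives > 1000000 nM as its entry, which is a limit of the assay and not a number. Compound 3 (`Cc1ccc(/C=C2\C(=O)c3ccccc3OC2c2ccccc2)cc1`) differs from compound 2 by methyl in place of hydrogen on an aromatic carbon, the change being phenyl to 4-methylphenyl. Among the compounds with values here, one measured step bears on this group: an at least 1400-fold higher number from compound 1 to compound 2 (3.15 log units; beyond the scatter) on exchange of pyridin-4-yl for phenyl, large and beyond the scatter. That step concerns a different change, so it gives only a loose guide to size. In this assay a modest move to a lower number is expected, though a result at the limit remains possible. The expected step is an at least 5.0-fold lower number from compound 2 to compound 3 (0.69 log units; beyond the scatter) as an estimate only. For compound 3 the estimated value is 200000 nM with an expected range from 5000 nM to 1000000 nM (expected, not measured).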

Compound 3, half-maximal inhibitory concentration: > 1000000 nM
Compound 3: no number, only a limit; the forecaster's own chance of this, stated with the estimate: 45%; at least 5.0-fold (0.69 log units) between middle value and limit.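

In this assay, methyl on the aromatic carbon para to a large group does not bring the series back into the readable range, and the step between compound 2 and compound 3 cannot be read because both entries are limits: the limit of > 1000000 nM in this assay, at which 2 of the 3 values shown sit.

Exchange of pyridin-4-yl for 4-methylphenyl gives an at least 1400-fold higher number from compound 1 to compound 3 (3.15 log units; beyond the scatter). Within the data shown here, with a second ring of carbon only now at the limit, compound 1 remains the only compound of the three with a measured number.

From the compounds shown here alone, it remains open whether an amine or a carboxylic acid at the same place on the phenyl ring would give a measurable value, and whether pyridin-3-yl would keep activity near that of compound 1. Going by these compounds, the size of the methyl effect also remains unknown, since it has been seen only against a limit.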